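The compounds below may be only part of what the source reports. "The series", "measured", "known", "first", "only" and "open" are said of these compounds alone.

In an in vitro ADME assay on microsomes from liver (Homo sapiens) for pharmacokinetics (a higher number here means faster removal of the compound, a lower number slower removal), compound 2 `Cc1cc(S(=O)(=O)N2C=CNC(=O)[C@H]2CC(=O)N2CCCC(N(C)C)CC2)c(C)cc1Cl` gives 64 mL.min-1.g-1, the lower of the two numbers, while compound 1 `Cc1cc(S(=O)(=O)N2C=CNC(=O)[C@H]2CC(=O)N2CCC[C@H](N3CCCC3)C2)c(C)cc1Cl` gives 235 mL.min-1.g-1. Compound 3 `Cc1cc(S(=O)(=O)N2C=CNC(=O)[C@H]2CC(=O)N2CCC3(CCN(C)C3)C2)c(C)cc1Cl` carries one change from compound 2: a group of 10 heavy atoms (8 carbon, 2 nitrogen; 2 five-membered non-aromatic rings with 1 hetero atom each) in place of a group of 10 heavy atoms (8 carbon, 2 nitrogen; one seven-membered non-aromatic ring with 1 hetero atom), on a carbonyl carbon. Among the compounds with values here, the only measured step at this place is a 3.7-fold lower number from compound 1 to compound 2 (0.56 log units; beyond the scatter), and it swaps a different pair of groups. It therefore gives a rough size for changes here, but no firm direction. The estimated change is a 1.5-fold higher number from compound 2 to compound 3 (0.17 log units; within the scatter), so no clear step beyond the scatter is expected. For compound 3, the estimate is 95 mL.min-1.g-1, with an expected range from 35 mL.min-1.g-1 to 250 mL.min-1.g-1.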

Compound 3, intrinsic clearance in microsomes: 28 mL.min-1.g-1
For compound 3 the middle estimate is 3.4-fold (0.53 log units) above the measured one; the whole stated range lies above it.
By their numbers in this assay, from the lowest: compound 3; then compound 2; then compound 1.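

In this assay the group with 2 five-membered non-aromatic rings on the carbonyl carbon gives a 2.3-fold lower number from compound 2 to compound 3 (0.36 log units; beyond the scatter) and an 8.4-fold lower number from compound 1 to compound 3 (0.92 log units; beyond the scatter) and so holds the lowest number of the three. In the step from compound 2, the leaving and entering groups have the same heavy-atom, donor and acceptor counts, so those counts alone do not fix the number at this place. No measurement available here accounts for the difference. From the compounds shown here alone, whether a morpholine or a carboxylic acid on this carbonyl carbon would take the number lower remains open. Also open, going by these compounds, is whether the ranking of these groups holds with changes elsewhere on the shared core.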